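Compound 3 to compound 4: a step into the unknown

A few compounds are considered here, and "the series" means these few. Any claim that something is new, unique, unknown or untested is made for them only; others in the source may bear on it.

Compound 1 `CCOc1ccccc1-c1ccc(-c2nc3cnccc3c(NC(COC)C(N)=O)c2C#N)cc1`: 2.8
Compound 2 `CCOc1ccccc1-c1ccc(-c2nc3cnccc3c(NC(C(N)=O)C3CC3)c2C#N)cc1`: 3
Compound 3 `CCOc1ccccc1-c1ccc(-c2nc3cnccc3c(N[C@@H]3CCOC3=O)c2C#N)cc1`: 2.7

In a physicochemical assay for lipophilicity, read by HPLC, at pH 7.5 (on this read-out higher numbers stand for higher lipophilicity and lower numbers for lower lipophilicity), compound 3 gives 2.7, the lowest of the three numbers, but its neighbours sit close by: compound 1 gives 2.8 and compound 2 gives 3. The steps of a number 0.10 log units lower from compound 1 to compound 3 (within the scatter) and a number 0.30 log units lower from compound 2 to compound 3 (within the scatter) both stay within the scatter, as does a number 0.20 log units higher from compound 1 to compound 2 (within the scatter). The three measured compounds, which share one core and differ only in the group on the nitrogen on the aromatic ring, are therefore not told apart by this assay.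

Compound 4 `CCOc1ccccc1-c1ccc(-c2nc3cnccc3c(NC(C)C(=O)O)c2C#N)cc1` has not been measured. The change from compound 3 is 1-carboxyethyl in place of 2-oxooxolan-3-yl on a nitrogen on an aromatic ring. No measured step brings in a 1-carboxyethyl group, or any group with the count of donors and acceptors shown for it, so the three small steps above give no direct guide. Because a number 0.30 log units lower from compound 2 to compound 3 (within the scatter) stays within the scatter, the only lead is the counted difference itself, and the expectation is a step down, a number 1.50 log units lower from compound 3 to compound 4 (beyond the scatter). Compound 4 is estimated at 1.2, with a range from 0.4 to 2.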

Compound 4, distribution coefficient: 2.1
Estimate against measurement, compound 4: 0.90 log units below, outside the stated range (above it).
By their numbers in this assay, from the lowest: compound 4; then compounds 3, 1 and 2 (each within the scatter of the next).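

In this assay the place on a nitrogen on an aromatic ring does respond to a change of group: 1-carboxyethyl in place of 2-oxooxolan-3-yl gives a number 0.60 log units lower from compound 3 to compound 4 (beyond the scatter) and this is a step the assay can read. Set against the other two neighbours, the same group gives a number 0.70 log units lower from compound 1 to compound 4 (beyond the scatter) and a number 0.90 log units lower from compound 2 to compound 4 (beyond the scatter) so compound 4 is the lowest of the four and the only one that stands apart from the others. Among the compounds shown here, the swaps among the three earlier groups all stayed within the scatter, so 1-carboxyethyl is the first group here to leave it, though each of its steps is only modest.

Going by these compounds, in the step to compound 4 the ring of 2-oxooxolan-3-yl goes and the 1-carboxyethyl group comes in together, and it stays open which part of that change carries the step; a methyl ester or a primary amide on the same short chain, an amine, or a carboxylic acid on a longer chain could help pull those parts apart. No separate measurement bears on why the number moves.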